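Fluoro for trifluoromethyl on the aminopyridine: stability check

A few compounds are considered here, and "the series" means these few. Any claim that something is new, unique, unknown or untested is made for them only; others in the source may bear on it.

Measured compounds:
- compound 1 `Fc1ccc(-c2nc3cnc(Nc4ccccn4)cc3[nH]2)cc1C(F)(F)F`: 70%
- compound 2 `Fc1cnc(Nc2cc3[nH]c(-c4cccc(C(F)(F)F)c4)nc3cn2)c(F)c1`: 32%
- compound 3 `Fc1ccc(-c2nc3cnc(Nc4cc(C(F)(F)F)ccn4)cc3[nH]2)cc1F`: 91%

In an ADME assay on microsomes from liver (Homo sapiens) for metabolic stability, read by LC-MS, with a stated time of 30 min, tested at 0.1 uM (on this read-out lower numbers stand for a less stable compound and higher numbers for a more stable compound), compound 3 gives 91%, the highest of the three numbers. The nearest is compound 1 with 70%, a gap beyond the scatter; the furthest is compound 2 with 32%, a gap well beyond the scatter. No pair among these three differs in only one place, so no single-point step is available; the three values simply show that changes on either aryl part move the read-out over a wide span.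

Compound 4 `Fc1ccnc(Nc2cc3[nH]c(-c4ccc(F)c(F)c4)nc3cn2)c1` differs from compound 3 by fluoro in place of trifluoromethyl on an aromatic carbon. The change takes away the trifluoromethyl and puts a fluoro in its place; the rest of the molecule is kept.

With no measured step of this kind in the set, the direction is uncertain. Given that compound 3 sits at the top of the range and the other two compounds with different aryl substitution sit lower, a drop in this assay for compound 4 is expected, of moderate size. The estimated step of a number 21 percentage points lower from compound 3 to compound 4 (beyond the scatter) reflects this. Compound 4 is therefore estimated at 70%, with a plausible range from 48% to 90%.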

Compound 4, percent of the compound remaining in the Homo sapiens assay: 92%
For compound 4 the middle estimate is 22 percentage points below the measured one; the whole stated range lies below it.
By their numbers in the Homo sapiens assay, from the lowest: compound 2; then compound 1; then compounds 3 and 4 (each within the scatter of the next).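

In the Homo sapiens assay the change from trifluoromethyl to fluoro, on an aromatic carbon opposite the ring nitrogen, reads as a number 1 percentage points higher from compound 3 to compound 4 (within the scatter), so at this place the read-out does not tell the two groups apart. For the compounds shown here, this is the first one-place step, and it shows that the larger group can be replaced by the single fluoro with no change in this read-out beyond the scatter. The same change does separate the pair on solubility in a physicochemical assay for solubility, using the shake flask method, measured as kinetic solubility, with a stated time of 20 h, at pH 2; on this read-out higher numbers stand for higher solubility and lower numbers for lower solubility: the measured solubility of compound 3, < 5000 nM, and of compound 4, 166000 nM, an at least 33-fold higher number (1.52 log units; beyond the scatter)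

In the physicochemical assay compound 3 gives < 5000 nM, which is a limit of the assay and not a number. In the physicochemical assay compound 4 gives 166000 nM.

From the compounds shown here alone, this step is read only on the aryl part shared by compound 3 and compound 4, so whether it carries over to the aryl parts of compound 1 and compound 2 stays open. Also open, going by these compounds, is how other groups at this place, such as an amine, a carboxylic acid or a longer alkyl chain, would read in the Homo sapiens assay and in the physicochemical assay.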